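The compounds below may be only part of what the source reports. "The series", "measured", "known", "first", "only" and "open" are said of these compounds alone.

Measured compounds:
compound 1, `C#CCN(C)CCCCCOc1ccc2c(c1)OCCC2=O`, gives 6.04% in an ADME assay on BTI cells for inhibition of Amine oxidase [flavin-containing] A (Homo sapiens), read by fluorescence and Amplex Red, with a stated time of 15 min, tested at 100 uM; on this read-out lower numbers stand for less inhibition and higher numbers for more inhibition at the one concentration tested (going by the name of the read-out);
compound 2, `C#CCN(C)CCCCCCOc1ccc2c(c1)OCCC2=O`, gives 34.1% in this assay;
compound 3, `C#CCN(C)CCCCCOc1ccc(C=O)c(OC)c1`, gives 27.1% in this assay.

Compound 4, `C#CCN(C)CCCCCCOc1ccc(C=O)c(OC)c1`, has not yet been measured. It differs from compound 3 by (methyl(propargyl)amino)methyl in place of methyl(propargyl)amino on a saturated chain carbon, five bonds along the chain from an oxygen on an aromatic ring. The same kind of change, ((methyl(propargyl)amino)methyl in place of methyl(propargyl)amino on a saturated chain carbon, five bonds along the chain from an oxygen on an aromatic ring), separates compound 1 from compound 2, and there it made a step of a number 28.1 percentage points higher from compound 1 to compound 2 (beyond the scatter) in this assay. The two place descriptions are the same word for word, so the change occurs twice in all, each time on a saturated chain carbon, five bonds along the chain from an oxygen on an aromatic ring. The cores of compound 1 and compound 3 differ, but that difference is not broken down here; compound 3 sits within the scatter of compound 2 and beyond it from compound 1.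

Going by the values given here, for compound 4 a step of about a number 24.9 percentage points higher from compound 3 to compound 4 (beyond the scatter) is expected, resting on the one earlier step of a number 28.1 percentage points higher from compound 1 to compound 2 (beyond the scatter), with a wide margin since it rests on a single pair. Compound 4 is therefore estimated at 52%, between 28% and 76%.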

Compound 4, a percentage reported as inhibition, at one concentration (the size of the read-out at that concentration, not a potency): 37.4%
Compound 4: middle estimate off by 14.6 percentage points, on the high side, and the stated range covers the measured number.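

On the second core the change points the same way as on the first: in this assay, putting (methyl(propargyl)amino)methyl in place of methyl(propargyl)amino gives a number 10.3 percentage points higher from compound 3 to compound 4 (beyond the scatter) on a read-out that reflects one concentration rather than a potency. Going by these compounds alone, the direction therefore carries from one core to the other, but the size of the step does not: the same change on two cores in this assay, a number 28.1 percentage points higher (beyond the scatter) from compound 1 to compound 2 and a number 10.3 percentage points higher (beyond the scatter) from compound 3 to compound 4, 17.8 percentage points apart, beyond the scatter of two such steps With only two pairs, this does not show which part of the cores sets the size of the step, and it gives no rule for predicting the step on a third core.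

The compounds shown leave open whether going further out to 2-(methyl(propargyl)amino)ethyl would raise the number again or whether the rise would stop there. They also leave open how the step would behave if a simple dimethylamine replaced the methyl(propargyl)amino group at the end of the chain.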